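The source may hold more compounds than are shown below. What is called first, only, known or untested is meant among the compounds shown, and "the series" means these compounds.

Measured compounds in this series:
compound 1, `Nc1ncnc2c1c(-c1cnc3[nH]ccc3c1)nn2CCCCCCCCC(=O)NO`, gives 7470 nM in a functional assay on HeLa cells (Homo sapiens) for inhibition, read by MTT assay, with a stated time of 72 h; on this read-out higher numbers stand for weaker inhibition and lower numbers for stronger inhibition
compound 2, `Nc1ncnc2c1c(-c1cnc3[nH]ccc3c1)nn2CCCCCCCCCC(=O)NO`, gives 7560 nM in this assay
compound 3, `Nc1nc2cc(-c3nn(CCCCC(=O)NO)c4ncnc(N)c34)ccc2o1`, gives 32200 nM in this assay

Compound 1 and compound 2 share one core and differ only by (hydroxycarbamoyl)methyl in place of hydroxycarbamoyl on a saturated chain carbon, eight bonds along the chain from an aromatic nitrogen. The step of a 1.0-fold higher number from compound 1 to compound 2 (0.01 log units; within the scatter) leaves the two values indistinguishable. Compound 3 carries a different core; the difference between the two cores is not broken down here. Compound 3 stands highest of the three numbers, and its gap to compound 2, as to compound 1, lies beyond the scatter.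

Compound 4, `Nc1nc2cc(-c3nn(CCCCCC(=O)NO)c4ncnc(N)c34)ccc2o1`, is not yet measured. It differs from compound 3 by (hydroxycarbamoyl)methyl in place of hydroxycarbamoyl on a saturated chain carbon, four bonds along the chain from an aromatic nitrogen. This is the same kind of change as that from compound 1 to compound 2, not the same change: there the place was on a saturated chain carbon eight bonds along the chain from an aromatic nitrogen, here it is four bonds along the chain from an aromatic nitrogen, and the core is that of compound 3 rather than that of compound 1.

Among the measured compounds shown here, the step from compound 3 to compound 4 is expected to be a 1.1-fold lower number from compound 3 to compound 4 (0.03 log units; within the scatter), because the only earlier instance of this kind of change gave a 1.0-fold higher number from compound 1 to compound 2 (0.01 log units; within the scatter). That expectation rests on a single pair on a different core, so the range is kept wide. Compound 4 is estimated at 30000 nM, expected between 12000 nM and 75000 nM.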

Compound 4, half-maximal inhibitory concentration: 15400 nM
Compound 4: the middle estimate sits 1.9-fold (0.29 log units) above what was measured; measured number inside the range.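

On the core of compound 3, (hydroxycarbamoyl)methyl in place of hydroxycarbamoyl gives a 2.1-fold lower number from compound 3 to compound 4 (0.32 log units; beyond the scatter) in this assay, a modest step in the direction of stronger inhibition. Set beside the earlier step on the core of compound 1, this step cannot be told apart from it: the same change on two cores in this assay, a 1.0-fold higher number (0.01 log units; within the scatter) from compound 1 to compound 2 and a 2.1-fold lower number (0.32 log units; beyond the scatter) from compound 3 to compound 4, 2.1-fold (0.33 log units) apart, within the scatter of two such steps

Among the compounds shown here, the two cores therefore show no measurable difference in how this change acts, but this does not establish that its effect carries over unchanged: there is only one pair per core, only the step on the core of compound 3 lies beyond the scatter, and the change sits eight bonds along the chain from an aromatic nitrogen on one core and four bonds along on the other.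

The compounds shown leave open whether a longer chain on the core of compound 3 would continue in the same direction, and how the two cores compare when they carry the same chain. They also leave open whether anything depends on the hydroxycarbamoyl end itself, for instance whether a carboxylic acid or a primary amide at the chain end would keep the inhibition seen here.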